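The source may report more compounds than this note shows. Statements on the series, on what has been measured and on what is new or still open speak of the compounds shown alone.

Compound 1 `COc1cc(-c2cc(/C=C/C(=O)c3ccccc3)nc3cc(-c4ccccc4)nn23)cc(OC)c1OC` gives 18200 nM in a functional assay on A549 cells (Homo sapiens) for antiproliferative activity, read by MTT assay, with a stated time of 24 h; a lower number here means a stronger inhibitor, a higher number a weaker inhibitor. Among the compounds with values here, compound 2 `COc1ccc(/C=C/C(=O)c2cc(-c3cc(OC)c(OC)c(OC)c3)n3nc(-c4ccccc4)cc3n2)cc1` gives 21200 nM and stands highest of the two numbers so far, with compound 1 nearest; the step of a 1.2-fold higher number from compound 1 to compound 2 (0.07 log units; within the scatter) lies within the scatter. Compound 3 `COc1cc(/C=C/C(=O)c2cc(-c3cc(OC)c(OC)c(OC)c3)n3nc(-c4ccccc4)cc3n2)cc(OC)c1OC` carries 3,4,5-trimethoxyphenyl in place of 4-methoxyphenyl on a double-bonded chain carbon bound to a double-bonded chain carbon. Within the data shown here, the only measured step that bears on this change is a 1.2-fold higher number from compound 1 to compound 2 (0.07 log units; within the scatter), where one methoxy group entered on that same aryl group without moving the number beyond the scatter, so no step beyond the scatter is expected in this assay either. Compound 3 is therefore expected to give 20000 nM in this assay, between 8000 nM and 50000 nM, a step of a 1.1-fold lower number from compound 2 to compound 3 (0.03 log units; within the scatter).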

Compound 3, half-maximal inhibitory concentration: 25900 nM
Estimate against measurement, compound 3: 1.3-fold (0.11 log units) below; low and high end bracket the measured number.
By their numbers in this assay, from the lowest: compounds 1, 2 and 3 (each within the scatter of the next).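

In this assay, the step to the fully substituted aryl group is a 1.2-fold higher number from compound 2 to compound 3 (0.09 log units; within the scatter), so adding further methoxy groups to the 4-methoxyphenyl group leaves the number within the scatter. Across compounds 1, 2 and 3, neither the first methoxy group nor the later ones on this aryl group move the number beyond the scatter. No measurement shown here offers an explanation for this flat result.

Still open, on these data alone, is whether an amine or a carboxylic acid on this aryl group would move the number beyond the scatter. Also open, as far as these compounds go, is whether changes to the shared core would do so.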